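Amide terminus variation in a shared-core antiproliferative series

The source may report more compounds than this note shows. Statements on the series, on what has been measured and on what is new or still open speak of the compounds shown alone.

Measured compounds:
compound 1 `Cn1ccnc1NC(=O)c1cccc(Nc2ncc(F)c(Nc3ccc(F)cc3)n2)c1` gives 15100 nM
compound 2 `CN(C)CC(=O)Nc1cccc(Nc2ncc(F)c(Nc3ccc(F)cc3)n2)c1` gives 1210 nM

Among the measured compounds shown here, in a functional assay on DU-145 cells (Homo sapiens) for antiproliferative activity, read by sulforhodamine B assay, with a stated time of 3 days (on this read-out lower numbers stand for stronger inhibition of growth and higher numbers for weaker inhibition of growth), compound 1 stands at the highest of the two numbers, with compound 2 the only neighbour. For the measured compounds named here, the single measured step is a 12-fold lower number from compound 1 to compound 2 (1.10 log units; beyond the scatter), a large move to a lower number. Compound 3 `COc1cc(NC(=O)c2cccc(Nc3ncc(F)c(Nc4ccc(F)cc4)n3)c2)cc(OC)c1` keeps the core of compound 1 and changes the amide terminus: 3,5-dimethoxyphenyl in place of 1-methyl-1H-imidazol-2-yl on an amide-type nitrogen. Going by the values given here, no measured step bears directly on this change; the step from compound 1 to compound 2 exchanges the whole terminus, carbonyl placement included, so it shows only that the imidazolyl amide of compound 1 is not the best terminus seen, not how a dimethoxyphenyl amide would behave. The expectation is therefore a modest move to a lower number at most, with wide uncertainty. Compound 3 is expected to give 8000 nM in this assay, within 2000 nM to 30000 nM. This estimate amounts to an expected step of a 1.9-fold lower number from compound 1 to compound 3 (0.28 log units; within the scatter).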

Compound 3, concentration for 50% growth inhibition: 13700 nM
The estimate for compound 3 lay 1.7-fold (0.23 log units) below the measured number, and the stated range covers the measured number.
By their numbers in this assay, from the lowest: compound 2; then compounds 3 and 1 (each within the scatter of the next).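

In this assay the exchange of 1-methyl-1H-imidazol-2-yl for 3,5-dimethoxyphenyl on the amide-type nitrogen gives a 1.1-fold lower number from compound 1 to compound 3 (0.04 log units; within the scatter) and so stays within the scatter. Among the compounds shown here, this is the first direct reading at this position with the carbonyl placement held fixed: a five-membered aromatic ring with 2 hetero atoms and a six-membered aromatic ring of carbon only, the latter with more heavy atoms, give numbers that cannot be told apart here. No supporting measurement accounts for this result.

Two aromatic termini cannot show whether this amide position responds to any change. A longer chain ending in a dimethylamino group, placed on the same amide-type nitrogen, would test whether this carbonyl placement can reach the range of compound 2 at 1210 nM.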